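Bromomethyl on the carbonyl carbon: expectation for compound 3

This account rests on a few compounds, and the source may have more. Where it says the series, first, only, none or still open, it means among the compounds named here.

In a functional assay on MGC-803 cells (Homo sapiens) for inhibition, read by MTT assay, with a stated time of 48 h (on this read-out higher numbers stand for weaker inhibition and lower numbers for stronger inhibition), compound 1 `CCCCC(=O)N(Cc1ccc(OC)c(O)c1)c1cc(OC)c(OC)c(OC)c1` gives 66 nM and compound 2 `COc1ccc(CN(C(=O)/C=C/CBr)c2cc(OC)c(OC)c(OC)c2)cc1O` gives 71 nM, so compound 2 stands within the scatter of compound 1. Compound 3 `COc1ccc(CN(C(=O)CBr)c2cc(OC)c(OC)c(OC)c2)cc1O` carries bromomethyl in place of 3-bromoprop-1-en-1-yl on a carbonyl carbon. Among the compounds with values here, the only measured step at this place, a 1.1-fold higher number from compound 1 to compound 2 (0.03 log units; within the scatter), exchanged butyl for 3-bromoprop-1-en-1-yl and stayed within the scatter. One step is thin evidence, but no change beyond the scatter is expected in this assay. The expected step is a 1.1-fold lower number from compound 2 to compound 3 (0.04 log units; within the scatter). For compound 3 the estimate is 65 nM, with an expected range of 22 nM to 190 nM.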

Compound 3, half-maximal inhibitory concentration: 140 nM
Compound 3: the middle estimate sits 2.2-fold (0.33 log units) below what was measured; low and high end bracket the measured number.
By their numbers in this assay, from the lowest: compounds 1, 2 and 3 (each within the scatter of the next, the first and the last beyond it).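

Working notes: in this assay, bromomethyl gives the first step at this position that lies beyond the scatter, though modest and only against butyl (a 2.1-fold higher number from compound 1 to compound 3 (0.33 log units; beyond the scatter)). Against 3-bromoprop-1-en-1-yl the same group stays within the scatter (a 2.0-fold higher number from compound 2 to compound 3 (0.29 log units; within the scatter)), so the position is not indifferent to every group, yet the two bromine-bearing groups remain unseparated. No measured evidence bears on this result.

Still open, going by these compounds, is whether the bromine matters at all, since a plain methyl on the carbonyl carbon would test that directly. On these data alone, how an amine such as dimethylaminomethyl or a longer bromoalkyl chain would read here also remains open.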